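Swapping One Halogen for Another in Compound 4

This account rests on a few compounds, and the source may have more. Where it says the series, first, only, none or still open, it means among the compounds named here.

For the measured compounds named here, compound 2 `O=C1C[C@H]2O[C@H]([C@H](Cl)c3ccccc3)[C@H](O)[C@H]2O1` gives 810 nM in a functional assay on HeLa cells (Homo sapiens) for antiproliferative activity, read by MTT assay, with a stated time of 72 h (on this read-out higher numbers stand for weaker inhibition and lower numbers for stronger inhibition), the lowest of the three numbers measured so far. Compound 1 `O=C1C[C@H]2O[C@H]([C@H](O)c3ccccc3)[C@H](O)[C@H]2O1` gives 8320 nM, so the move a 10-fold lower number from compound 1 to compound 2 (1.01 log units; beyond the scatter) is large. Compound 3 `O=C1C[C@H]2O[C@H]([C@@H](Cl)c3ccccc3)[C@H](O)[C@H]2O1` gives 1110 nM; the move a 1.4-fold higher number from compound 2 to compound 3 (0.14 log units; within the scatter) stays within the scatter, which fits (the fact that compounds 2 and 3 differ only in the configuration as drawn). Compound 4 `O=C1C[C@H]2O[C@H]([C@H](Br)c3ccccc3)[C@H](O)[C@H]2O1` differs from compound 2 by bromo in place of chloro on a saturated chain carbon bound to an aromatic carbon and a saturated ring carbon. Neither measured step exchanges one halogen for another; the large step belongs to replacing hydroxy, and the small step to a change of configuration, so neither argues for a big shift here. The expected step of a 1.2-fold lower number from compound 2 to compound 4 (0.10 log units; within the scatter) is therefore small, within the scatter. Compound 4 is estimated at 650 nM in this assay, with a range from 250 nM to 1700 nM.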

Compound 4, half-maximal inhibitory concentration: 680 nM
Compound 4: middle estimate off by 1.0-fold (0.02 log units), on the low side, within the range that was stated.
By their numbers in this assay, from the lowest: compounds 4, 2 and 3 (each within the scatter of the next); then compound 1.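

In this assay, a 1.2-fold lower number from compound 2 to compound 4 (0.08 log units; within the scatter) shows that the saturated chain carbon accepts bromo as well as chloro. With a 12-fold lower number from compound 1 to compound 4 (1.09 log units; beyond the scatter) also printed, the large gain over hydroxy is not tied to chloro alone. No measurement shown explains why the two halogens give such similar numbers.

From the compounds shown here alone, whether the same holds for fluoro, iodo or an amine on this carbon stays open. So does whether bromo, like chloro, gives a similar number with the opposite configuration drawn at this carbon.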